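The source may hold more compounds than are shown below. What is called first, only, known or untested is meant among the compounds shown, and "the series" means these compounds.

Compound 1 `FC(F)(F)c1ccc(CSc2nc(N3CCCCC3)c3ccccc3n2)cc1`: 25500 nM
Compound 2 `O=[N+]([O-])c1cccc(Nc2nc(SCc3ccc(C(F)(F)F)cc3)nc3ccccc23)c1`: 13500 nM

In a functional assay on PC-3 cells (Homo sapiens) for cytotoxicity, read by MTT assay, with a stated time of 72 h (on this read-out lower numbers stand for stronger inhibition and higher numbers for weaker inhibition), compound 1 gives 25500 nM, the highest of the two numbers. Its nearest neighbour is compound 2, reached by a 1.9-fold lower number from compound 1 to compound 2 (0.28 log units; within the scatter). Compound 3 `FC(F)(F)c1ccc(CSc2nc(Nc3ccc(Cl)cc3)c3ccccc3n2)cc1` is not yet measured; it differs from compound 1 in one place: (4-chlorophenyl)amino in place of piperidin-1-yl on an aromatic carbon. Among the compounds with values here, the only step that bears on this change is the one from compound 1 to compound 2, where the same piperidin-1-yl gave way to an arylamino group with a small, within-scatter result. He therefore expects a small step, if any, toward a lower number, estimated as a 2.0-fold lower number from compound 1 to compound 3 (0.29 log units; within the scatter). Compound 3 is estimated at 13000 nM, in the range 4500 nM to 38000 nM.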

Compound 3, half-maximal inhibitory concentration: 7110 nM
Compound 3: middle estimate off by 1.8-fold (0.26 log units), on the high side; measured number inside the range.
By their numbers in this assay, from the lowest: compounds 3, 2 and 1 (each within the scatter of the next, the first and the last beyond it).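

In this assay, within the data shown here, (4-chlorophenyl)amino in place of piperidin-1-yl gives the first step at this position that lies beyond the scatter (a 3.6-fold lower number from compound 1 to compound 3 (0.55 log units; beyond the scatter)), whereas the step to (3-nitrophenyl)amino stayed within it. The two arylamino groups themselves do not separate (a 1.9-fold lower number from compound 2 to compound 3 (0.28 log units; within the scatter)). No measurement at hand explains the change.

The compounds shown leave open whether the step rests on the aromatic ring, the amino hydrogen or the chlorine. A plain phenylamino group or a methyl(phenyl)amino group in the same place would bear on this.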